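The compounds below may be only part of what the source reports. "The series", "measured", "known", "first", "only" and "open" are said of these compounds alone.

In an assay on isolated protein for inhibition of alpha-ketoglutarate-dependent dioxygenase alkB homolog 3 (Homo sapiens), read by polymerase chain reaction, with a stated time of 1 h (on this read-out higher numbers stand for weaker inhibition and lower numbers for stronger inhibition), three compounds share a core and have been measured. Compound 1 `Oc1c(-c2ccccc2)c(-c2ccccc2)nn1-c1nc2cc(Cl)ccc2[nH]1` gives 2000 nM. Compound 2 `Cc1[nH]n(-c2nc3ccccc3[nH]2)c(=O)c1Cc1ccc(-c2ccccc2)cc1` gives 720 nM, the lowest of the three numbers, and so the strongest inhibition seen here. Compound 3 `Cc1ccc2[nH]c(-n3[nH]c(C)c(Cc4ccc(-c5ccccc5)cc4)c3=O)nc2c1` gives 5300 nM. Going by the values given here, the single step between neighbours that differ in one place is a 7.4-fold higher number from compound 2 to compound 3 (0.87 log units; beyond the scatter), a methyl in place of hydrogen on an aromatic carbon of the core.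

Compound 4 `Cc1[nH]n(-c2nc3ccccc3[nH]2)c(=O)c1Cc1ccc(C(F)(F)F)cc1` is built from compound 2 by a change at the other end of the molecule: trifluoromethyl in place of phenyl on an aromatic carbon. Among the compounds with values here, no measured step bears on this change; the step from compound 2 to compound 3 concerns a different place and a different group, and compound 1 differs from compound 2 in several places at once. A sizeable group is removed and a smaller one put on the same aromatic carbon, para to a large group, so a loss of inhibition beyond the scatter is expected, with wide uncertainty, estimated as a 3.5-fold higher number from compound 2 to compound 4 (0.54 log units; beyond the scatter). Compound 4 is therefore estimated to give 2500 nM, within the range 600 nM to 10000 nM.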

Compound 4, half-maximal inhibitory concentration: 550 nM
The estimate for compound 4 lay 4.5-fold (0.66 log units) above the measured number; the whole stated range lies above it.
By their numbers in this assay, from the lowest: compounds 4 and 2 (each within the scatter of the next); then compound 1; then compound 3.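

The step at this place is a 1.3-fold lower number from compound 2 to compound 4 (0.12 log units; within the scatter), so in this assay the second phenyl ring of compound 2 is not needed to keep inhibition at this level: trifluoromethyl, with no ring and fewer heavy atoms, serves as well on this aromatic carbon. Going by these compounds alone, this end of the molecule therefore accepts two very different groups, whereas the single change seen elsewhere, a 7.4-fold higher number from compound 2 to compound 3 (0.87 log units; beyond the scatter), lies beyond the scatter. Nothing available explains why phenyl and trifluoromethyl read alike here.

Going by these compounds, it remains open whether plain hydrogen, an amine or a carboxylic acid on this carbon would also read alike, which would show how much of any group is needed here. On these data alone, it is also open whether trifluoromethyl would match phenyl in the same way with the extra methyl of compound 3 on the core.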